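Imide nitrogen substituents against lactase/phlorizin hydrolase

The compounds below may be only part of what the source reports. "The series", "measured", "known", "first", "only" and "open" are said of these compounds alone.

Values in an assay on isolated protein for inhibition of lactase/phlorizin hydrolase (Rattus norvegicus), read by colorimetric assay; on this read-out higher numbers stand for weaker inhibition and lower numbers for stronger inhibition:
compound 1 `Cc1ccc(S(=O)(=O)Nc2ccc3c(c2)C(=O)N(CCNc2ccc(O)c(O)c2)C3=O)cc1`: 66600 nM
compound 2 `Cc1ccc(S(=O)(=O)Nc2ccc3c(c2)C(=O)N(Cc2ccccc2)C3=O)cc1`: > 200000 nM, a limit of the assay, not a number
compound 3 `Cc1ccc(S(=O)(=O)Nc2ccc3c(c2)C(=O)N(Cc2ccc(Cl)c(Cl)c2)C3=O)cc1`: 101000 nM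

Compound 3 carries the highest of the two numbers, and compound 1 lies nearest, the step of a 1.5-fold higher number from compound 1 to compound 3 (0.18 log units; within the scatter) falling within the scatter. Compound 2 gives only a limit (the limit of > 200000 nM in this assay, at which 1 of the 3 values shown sits).

Compound 4 `Cc1ccc(S(=O)(=O)Nc2ccc3c(c2)C(=O)N(CCOc2cccc(O)c2)C3=O)cc1` differs from compound 3 by (3-hydroxyphenoxy)methyl in place of 3,4-dichlorophenyl on a saturated chain carbon bound to an amide-type nitrogen in a ring. Going by the values given here, the steps that bear on this are a 1.5-fold higher number from compound 1 to compound 3 (0.18 log units; within the scatter) and an at least 1.9-fold lower number from compound 2 to compound 3 (0.29 log units; that floor lies within the scatter), both small, so swapping the aryl group on the chain carbon has so far moved nothing beyond the scatter. Accordingly the expected step is a 1.3-fold lower number from compound 3 to compound 4 (0.10 log units; within the scatter), none beyond the scatter. Compound 4 is therefore estimated at 80000 nM, with a range from 30000 nM to 200000 nM.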

Compound 4, half-maximal inhibitory concentration: 111000 nM
The estimate for compound 4 lay 1.4-fold (0.14 log units) below the measured number; the range from low to high includes it.
By their numbers in this assay, from the lowest: compounds 1, 3 and 4 (each within the scatter of the next). At a limit, above all of these: compound 2.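

At this position in this assay, 2-(3-hydroxyphenoxy)ethyl cannot be told apart from 3,4-dichlorobenzyl, with a 1.1-fold higher number from compound 3 to compound 4 (0.04 log units; within the scatter), although the entering group adds a hydrogen-bond donor and acceptors. Exchanging (3,4-dihydroxyphenyl)amino for 3-hydroxyphenoxy on the chain likewise gives only a 1.7-fold higher number from compound 1 to compound 4 (0.22 log units; within the scatter). The step of an at least 1.8-fold lower number from compound 2 to compound 4 (0.25 log units; that floor lies within the scatter) starts from a limit of the assay, not a number: the limit of > 200000 nM in this assay, at which 1 of the 4 values shown sits.

On these data alone, whether any group here can move the number beyond the scatter remains open. A primary amine, a carboxylic acid or a longer chain at this position would test that.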